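The source may hold more compounds than are shown below. What is called first, only, known or untested is meant among the compounds shown, and "the series" means these compounds.

Three measured compounds share one core. Compound 1 `COC(=O)N1CCC(Oc2ncnc(Oc3ccc(/C=C4\SC(=O)NC4=O)cc3)c2C)CC1`, compound 2 `CCOC(=O)N1CCC(Oc2ncnc(Oc3ccc(/C=C4\SC(=O)NC4=O)cc3)c2C)CC1` and compound 3 `CCOC(=O)N1CCC(Oc2cc(Oc3ccc(/C=C4\SC(=O)NC4=O)cc3)ncn2)CC1` were all tested in a functional assay on CHO-K1 cells for agonist activity at Glucose-dependent insulinotropic receptor (Homo sapiens), read by cAMP accumulation and immunoassay, with a stated time of 1 h; a higher number here means a larger maximal response, a lower number a smaller maximal response. Compound 1 gives 53.3%, compound 2 gives 141%, and compound 3 gives 51.8%. Compound 3 has the lowest of the three numbers, but compound 1 lies within the scatter of it, while compound 2 stands far above both.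

Compound 4 `O=C1NC(=O)/C(=C/c2ccc(Oc3cc(OC4CCN(C(=O)OCc5ccccc5)CC4)ncn3)cc2)S1` has not yet been measured. It differs from compound 3 by phenyl in place of methyl on a saturated chain carbon bound to an oxygen next to a carbonyl group, which can also be read as ethoxycarbonyl becoming benzyloxycarbonyl. Among the compounds with values here, two measured steps bear on this. The step of a number 87.7 percentage points higher from compound 1 to compound 2 (beyond the scatter) enlarged the same carbamate end by a single carbon and produced a large rise. The step of a number 89.2 percentage points lower from compound 2 to compound 3 (beyond the scatter) shows that removing the methyl from the aromatic carbon, which compound 4 also lacks, produced a large fall. Since compound 4 again grows the carbamate end, a rise beyond the scatter is expected, though with wide uncertainty. Compound 4 is therefore expected to reach 90%, with a range from 40% to 150%, an expected step of a number 38.2 percentage points higher from compound 3 to compound 4 (beyond the scatter).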

Compound 4, largest response reached (Emax), in percent of the reference or control that the assay uses: 88.3%
For compound 4 the middle estimate is 1.7 percentage points above the measured one, and the stated range covers the measured number.
By their numbers in this assay, from the lowest: compounds 3 and 1 (each within the scatter of the next); then compound 4; then compound 2.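

In this assay, the step of a number 36.5 percentage points higher from compound 3 to compound 4 (beyond the scatter) shows that the carbamate end still affects the response on the core lacking the aromatic methyl, whereas the earlier change at this end was seen with that methyl present. It also shows that this position is not limited to small alkyl chains: ethoxycarbonyl becoming benzyloxycarbonyl brings in a six-membered aromatic ring of carbon only, and the maximal response rises. No measured evidence here explains this rise.

The compounds shown leave open whether the phenyl ring itself matters, or whether a longer chain such as butyl at the same place would give a similar response. They also leave open how benzyloxycarbonyl behaves on the core carrying the aromatic methyl, and what an amine or a carboxylic acid on the phenyl group would do.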